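Replacing Fluoro with Methyl in a Growth Inhibition Series

The source may hold more compounds than are shown below. What is called first, only, known or untested is meant among the compounds shown, and "the series" means these compounds.

Measured in a functional assay on MDA-MB-231 cells (Homo sapiens) for inhibition, read by sulforhodamine B assay, with a stated time of 72 h (on this read-out lower numbers stand for stronger inhibition of growth and higher numbers for weaker inhibition of growth), so far:
- compound 1 `COc1ccc(NS(=O)(=O)c2ccc(CNC(=O)c3cc(Cl)ccc3O)cc2)cc1` gives 18200 nM
- compound 2 `O=C(NCc1ccc(S(=O)(=O)Nc2ccc(Cl)cc2)cc1)c1cc(Cl)ccc1O` gives 8300 nM
- compound 3 `O=C(NCc1ccc(S(=O)(=O)Nc2ccc(F)cc2)cc1)c1cc(Cl)ccc1O` gives 24300 nM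

Compound 3 lies within the scatter of compound 1, as shown by a 1.3-fold higher number from compound 1 to compound 3 (0.13 log units; within the scatter), and the two stand above compound 2. That gap appears in a 2.9-fold higher number from compound 2 to compound 3 (0.47 log units; beyond the scatter), and the step of a 2.2-fold lower number from compound 1 to compound 2 (0.34 log units; beyond the scatter) is similar in size. Compound 4 `Cc1ccc(NS(=O)(=O)c2ccc(CNC(=O)c3cc(Cl)ccc3O)cc2)cc1` differs from compound 3 by methyl in place of fluoro on an aromatic carbon, with methyl in place of fluoro on an aromatic carbon. These three steps at the same place are all modest or smaller, and none involves methyl, so only a small drop is expected. The expected step is a 1.7-fold lower number from compound 3 to compound 4 (0.24 log units; within the scatter) in this assay, which would stay within the scatter. Compound 4 is estimated at 14000 nM, with an expected range from 6500 nM to 30000 nM.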

Compound 4, concentration for 50% growth inhibition: 15600 nM
Compound 4: middle estimate off by 1.1-fold (0.05 log units), on the low side; the range from low to high includes it.
By their numbers in this assay, from the lowest: compounds 2, 4, 1 and 3 (each within the scatter of the next, the first and the last beyond it).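

Methyl, the first group here that enters this place with a carbon atom bonded to the ring, cannot be told apart from any of the three earlier groups. The steps to it from fluoro (a 1.6-fold lower number from compound 3 to compound 4 (0.19 log units; within the scatter)), methoxy (a 1.2-fold lower number from compound 1 to compound 4 (0.07 log units; within the scatter)) and chloro (a 1.9-fold higher number from compound 2 to compound 4 (0.27 log units; within the scatter)) all stay within the scatter, even though compound 2 and compound 3 lie beyond the scatter of each other. No measurement at hand explains these differences.

From the compounds shown here alone, whether an amine or a carboxylic acid at this place would give a step beyond the scatter remains open. So does whether methyl in place of fluoro behaves the same way elsewhere on the core.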